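Pyrrolidin-1-yl for Methylsulfanyl: Expected Effect on Cytotoxicity

The source may report more compounds than this note shows. Statements on the series, on what has been measured and on what is new or still open speak of the compounds shown alone.

Three compounds have been measured in a functional assay on Hs 683 cells (Homo sapiens) for cytotoxicity, read by MTT assay, with a stated time of 72 h; on this read-out higher numbers stand for weaker inhibition and lower numbers for stronger inhibition:

compound 1, `CSc1nc(Cl)c(C(=O)c2ccccc2)s1`: > 100000 nM, which is a limit of the assay rather than a number
compound 2, `O=C(c1ccccc1)c1sc(N2CCCC2)nc1Cl`: 44000 nM
compound 3, `COC(=O)c1sc2nc(SC)sc2c1C`: 79000 nM

Compound 1 and compound 2 differ in one place, (pyrrolidin-1-yl in place of methylsulfanyl on an aromatic carbon). This change gave an at least 2.2-fold lower number from compound 1 to compound 2 (0.35 log units; beyond the scatter); the step can only be given as a lower bound because of the limit of > 100000 nM in this assay, at which 1 of the 3 values shown sits. Compound 2 and compound 3 sit within the usual scatter of each other, so their values cannot be ordered.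

Compound 3 carries a different core from compound 1; how the two cores differ is not broken down here. Compound 4, `COC(=O)c1sc2nc(N3CCCC3)sc2c1C`, is not yet measured and differs from compound 3 by pyrrolidin-1-yl in place of methylsulfanyl on an aromatic carbon. This is the same kind of change as that from compound 1 to compound 2, but the surroundings differ: in compound 4 the ring is part of a fused or bridged system of two rings, whereas in compound 2 the ring carbon is two ring bonds from the ring atom that bears a chloro group and from the ring atom that bears a group of 8 heavy atoms.

Compound 4 is expected to show a 2.2-fold lower number from compound 3 to compound 4 (0.34 log units; beyond the scatter), resting on the step from compound 1 to compound 2, an at least 2.2-fold lower number from compound 1 to compound 2 (0.35 log units; beyond the scatter), in this assay. Compound 4 is therefore estimated at 36000 nM, with a likely range from 15000 nM to 100000 nM.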

Compound 4, half-maximal inhibitory concentration: 91000 nM
Compound 4: middle estimate off by 2.5-fold (0.40 log units), on the low side; measured number inside the range.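

In this assay, putting pyrrolidin-1-yl in place of methylsulfanyl on the core with a fused system of two rings gave a 1.2-fold higher number from compound 3 to compound 4 (0.06 log units; within the scatter), so this pair shows no clear effect of the change. The lower number seen on the core of compound 1 therefore cannot simply be assumed to carry over to this other core, although this single pair does not prove that the two cores truly respond differently. Whether the two steps differ cannot be settled from these values: the same change on two cores in this assay, an at least 2.2-fold lower number (0.35 log units; beyond the scatter) from compound 1 to compound 2 and a 1.2-fold higher number (0.06 log units; within the scatter) from compound 3 to compound 4; the limit leaves it open whether they differ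

With pyrrolidin-1-yl as the only amine shown in this position, it remains open how an open-chain amine such as dimethylamino, or a six-membered one such as morpholin-4-yl, would behave on either core. From the compounds shown here alone, it is also open whether the result on the fused core would hold if its methyl ester gave way to a carboxylic acid or an amide.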